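One Amide Substituent Swap on a Shared Core

The compounds below may be only part of what the source reports. "The series", "measured", "known", "first", "only" and "open" are said of these compounds alone.

Compound 1 `Cc1ccc(NC(=O)COc2ccc3cc(/C=C4/SC(=O)NC4=O)ccc3c2)cc1` gave 9000 nM in an assay on isolated protein for inhibition of histone deacetylase 8 (Homo sapiens), with a stated time of 1 h; on this read-out lower numbers stand for stronger inhibition and higher numbers for weaker inhibition. Compound 2 `CCOc1ccc2nc(NC(=O)COc3ccc4cc(/C=C5/SC(=O)NC5=O)ccc4c3)sc2c1` gave 17000 nM. Compound 3 `O=C(COc1ccc2cc(/C=C3/SC(=O)NC3=O)ccc2c1)Nc1cccc(F)n1` gave 7200 nM.

Compound 3 stands at the lowest of the three numbers; its gap to compound 1 lies within the scatter, while compound 2 sits beyond it. Compound 4 `O=C(COc1ccc2cc(/C=C3/SC(=O)NC3=O)ccc2c1)Nc1cccc(C(F)(F)F)c1` differs from compound 3 in one place: 3-(trifluoromethyl)phenyl in place of 6-fluoropyridin-2-yl on an amide-type nitrogen. Going by the values given here, only one measured step bears on this position, the earlier change of the amide substituent, which gave a 1.3-fold lower number from compound 1 to compound 3 (0.10 log units; within the scatter). Since that swap of one aryl group for another barely moved the number, a further aryl swap is expected to produce no step beyond the scatter. For compound 4 the estimate is therefore 8000 nM, with a range from 3000 nM to 20000 nM, meaning an expected step of a 1.1-fold higher number from compound 3 to compound 4 (0.05 log units; within the scatter).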

Compound 4, half-maximal inhibitory concentration: > 50000 nM
Compound 4 ended at the assay's limit; the forecaster's own chance of this, stated with the estimate: 5%; middle value at least 6.2-fold (0.79 log units) away from the limit.
By their numbers in this assay, from the lowest: compounds 3, 1 and 2 (each within the scatter of the next, the first and the last beyond it). At a limit, above all of these: compound 4.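

This position on the amide-type nitrogen is not indifferent to the aryl group it carries, as the earlier swap suggested: 3-(trifluoromethyl)phenyl gives an at least 6.9-fold higher number from compound 3 to compound 4 (0.84 log units; beyond the scatter), and likewise an at least 5.5-fold higher number from compound 1 to compound 4 (0.74 log units; beyond the scatter). Both steps lie beyond the scatter, unlike the step between compounds 1 and 3. The value of compound 4 is a limit and not a number: the limit of > 50000 nM in this assay, at which 1 of the 4 values shown sits.

On these data alone, how far the true value of compound 4 lies past that limit stays open. So does whether an amine or a carboxylic acid on this phenyl ring would keep the number within the scatter of compound 3.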